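A few compounds are considered here, and "the series" means these few. Any claim that something is new, unique, unknown or untested is made for them only; others in the source may bear on it.

Compound 1 `O=C(Nc1ccc(Cl)cc1)C1CCCN(C(=O)c2cccc(-c3nccs3)c2)C1` sits in the middle of the three numbers measured: in an ADME assay on PC-3 cells (Homo sapiens) for cytotoxicity, read by WST assay, tested at 100 uM (on this read-out lower numbers stand for less inhibition and higher numbers for more inhibition at the one concentration tested (going by the name of the read-out)), compound 1 gives 32%. Compound 2 `O=C(Nc1cccc(CN2CCCC2)c1)C1CCCN(C(=O)c2cc(C(F)(F)F)cc(C(F)(F)F)c2)C1` gives 51% in this assay, and compound 3 `O=C(Nc1cccc(Cc2ccccc2)c1)C1CCCN(C(=O)c2cc(C(F)(F)F)cc(C(F)(F)F)c2)C1` gives 0%, so compound 1 lies below compound 2 and above compound 3, in both cases by more than the usual scatter.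

Compound 4 `O=C(Nc1ccc(Cl)cc1)C1CCCN(C(=O)c2cccc(-c3cnco3)c2)C1` differs from compound 1 in one place, where 1,3-oxazol-5-yl in place of 1,3-thiazol-2-yl on an aromatic carbon replaces one five-membered aromatic ring with two hetero atoms by another of the same size on the six-membered aromatic ring of carbon only. Among the measured compounds shown here, the only measured step, a number 51 percentage points lower from compound 2 to compound 3 (beyond the scatter), concerns a different position on a different core, and so gives no guidance on this exchange. For the measured compounds named here, no measured pair therefore bears on the change from compound 1 to compound 4, and with two rings of matching size and the same count of acceptors he expects no step beyond the scatter. Compound 4 is accordingly expected to give about 30% in this assay, with a range from 10% to 55%, so that the step of a number 2 percentage points lower from compound 1 to compound 4 (within the scatter) is estimated to stay within the scatter.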

Compound 4, a percentage reported as inhibition, at one concentration (the size of the read-out at that concentration, not a potency): 0%
Estimate against measurement, compound 4: 30 percentage points above; the whole stated range lies above it.
By their numbers in this assay, from the lowest: compounds 3 and 4 (each within the scatter of the next); then compound 1; then compound 2.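

In this assay, putting 1,3-oxazol-5-yl in place of 1,3-thiazol-2-yl on the aromatic carbon gives a number 32 percentage points lower from compound 1 to compound 4 (beyond the scatter), the first step seen at this place, and it shows that the read-out here depends on which five-membered aromatic ring is attached. The two groups have the same counts of heavy atoms, hydrogen-bond donors and hydrogen-bond acceptors and carry no net charge, so these counts alone do not settle the read-out at this place. Nothing available explains this step.

The compounds shown leave open whether the step goes with oxygen in place of sulfur or with the different point of attachment of the ring. They also leave open how 1,3-thiazol-5-yl, 1,3-oxazol-2-yl or a carboxylic acid on this aromatic carbon would read in this assay.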